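The source may hold more compounds than are shown below. What is called first, only, known or untested is meant among the compounds shown, and "the series" means these compounds.

Compound 1 `C/C(=N\OCC(=O)O)c1ccccc1` — in a functional assay on the whole organism for inhibition, with Rattus norvegicus as the target, read by paw edema, with stated times of 1 h and 3 h, at a dose of 50 mg/kg by the oral route (a higher number here means more inhibition at the dose given (going by the name of the read-out), a lower number less inhibition), compound 1 gives < 20%
Compound 2 `C/C(=N\OCC(=O)O)c1ccccc1Cl` — compound 2 gives < 20%
Compound 3 `C/C(=N\OCC(=O)O)c1ccccc1O` — compound 3 gives < 20%

Each of these three values is a limit of this assay, not a number. Compound 3 therefore stands at the limit < 20% in this assay, and nothing can be read of where it lies beneath that limit. The steps a step that the two limits leave unreadable from compound 1 to compound 2, a step that the two limits leave unreadable from compound 1 to compound 3 and a step that the two limits leave unreadable from compound 2 to compound 3 are all unreadable in size because of the limit of < 20% in this assay, at which 3 of the 3 values shown sit.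

The shared core of compound 3 is kept in compound 4 `C/C(=N\OCC(=O)O)c1ccccc1C(=O)O`; the change is carboxy in place of hydroxy on an aromatic carbon. Among the measured compounds shown here, no measured step bears on this change: chloro for hydrogen, hydroxy for hydrogen and hydroxy for chloro each ran between two limits and gave nothing that could be read. From the data alone no step size in this assay can be expected in either direction; the only indication is that all three measured compounds sit at the limit, so a fourth value at the limit is the likeliest outcome. For compound 4 the estimate is 15%, in the range 0% to 35%, most probably reported again as a limit. The expected step that the limit leaves unreadable from compound 3 to compound 4 is accordingly taken as none beyond the scatter.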

Compound 4, a percentage reported as inhibition, in the whole organism at one dose (the size of the read-out at that dose, not a potency): < 20%
Compound 4 gave a limit, no number; the forecaster's own chance of this, stated with the estimate: 70%; the middle value lies beyond the limit too.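

In this assay compound 4 gives < 20% as a limit, not a number. No new step can be read, and the steps to compound 4 from compound 1, compound 2 and compound 3 remain unreadable in size because all four compounds share one limit: the limit of < 20% in this assay, at which 4 of the 4 values shown sit.

The compounds shown leave open whether any group at this aromatic carbon gives inhibition that can be read as a number.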